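The source may hold more compounds than are shown below. What is called first, only, known or untested is meant among the compounds shown, and "the series" means these compounds.

Compound 2 `C=CCc1cc(-c2ccc(O)c(CC=C)c2)c(O)c(C(c2cc(Cl)cc(Cl)c2)N2CCCCC2)c1` gives 23500 nM in an assay on isolated protein for inhibition of Maltase-glucoamylase (Homo sapiens), with stated times of 15 min and 10 min; a lower number here means a stronger inhibitor, a higher number a weaker inhibitor; compound 1 `C=CCc1cc(-c2ccc(O)c(CC=C)c2)c(O)c(C(c2ccc(OC)cc2)N2CCCCC2)c1` gives 30500 nM in this assay, and the step of a 1.3-fold lower number from compound 1 to compound 2 (0.11 log units; within the scatter) lies within the scatter, so the two stand together. Compound 3 `C=CCc1cc(-c2ccc(O)c(CC=C)c2)c(O)c(C(c2cc(Cl)cc(Cl)c2)N2CCC(C)CC2)c1` differs from compound 2 by methyl in place of hydrogen on a saturated ring carbon, read one bond further out as piperidin-1-yl to 4-methylpiperidin-1-yl. Among the compounds with values here, no measured step touches this ring; the only step in hand exchanged the aryl group and stayed within the scatter. In this assay the expected change is therefore none beyond the scatter, and compound 3 is estimated at 23500 nM (range 9000 nM to 60000 nM), an expected step of no change at the digits printed from compound 2 to compound 3 (within the scatter).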

Compound 3, half-maximal inhibitory concentration: 14900 nM
The estimate for compound 3 lay 1.6-fold (0.20 log units) above the measured number; low and high end bracket the measured number.
By their numbers in this assay, from the lowest: compounds 3, 2 and 1 (each within the scatter of the next, the first and the last beyond it).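

In this assay, methyl on the saturated ring carbon, three ring bonds from the ring nitrogen, gives a 1.6-fold lower number from compound 2 to compound 3 (0.20 log units; within the scatter) and so stays within the scatter. Within the data shown here, this is the first reading on this ring: read as piperidin-1-yl to 4-methylpiperidin-1-yl, the added methyl is accepted without a step beyond the scatter. No evidence bears on the reason for this result.

Open, going by these compounds, is whether a hydroxyl, an amine or a longer chain on this ring carbon would give a step beyond the scatter. Also open, on these data alone, is whether methyl reads the same with the 4-methoxyphenyl group of compound 1.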